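This account rests on a few compounds, and the source may have more. Where it says the series, first, only, none or still open, it means among the compounds named here.

Two compounds of this series have numbers in an ADME assay on HepG2 cells (Homo sapiens) for cytotoxicity, read by luminescence, CellTiter-Glo and ATP content, with a stated time of 72 h; on this read-out lower numbers stand for an effect already at smaller amounts and higher numbers for an effect only at larger amounts of compound. Compound 1 `COc1ccc(Oc2ccc3c(NCCCNCc4ccco4)ccnc3c2)cc1` gives 5300 nM in this assay. Going by the values given here, compound 2 `c1coc(CNCCCNc2ccnc3cc(-c4cccc5ccccc45)ccc23)c1` gives 5600 nM in this assay, the highest of the two numbers, with compound 1 its nearest neighbour; the one measured step, a 1.1-fold higher number from compound 1 to compound 2 (0.02 log units; within the scatter), lies within the scatter, so no order between the two can be drawn.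

Compound 3 `COc1cccc(Oc2ccc3c(NCCCNCc4ccco4)ccnc3c2)c1` is not yet measured. Its change from compound 2: 3-methoxyphenoxy in place of naphthalen-1-yl on an aromatic carbon. Compound 1 carries 4-methoxyphenoxy at the same aromatic carbon, so compound 3 is its positional isomer and the step from compound 1 to compound 2 is the only one that bears on the change; that step was within the scatter. On that basis no step beyond the scatter is expected from compound 2 to compound 3: the expected change is a 1.0-fold lower number from compound 2 to compound 3 (0.01 log units; within the scatter). Compound 3 is therefore estimated at 5500 nM in this assay, expected to fall between 2500 nM and 12000 nM.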

Compound 3, half-maximal effective concentration: 15500 nM
Estimate against measurement, compound 3: 2.8-fold (0.45 log units) below; measured number above the stated range.
By their numbers in this assay, from the lowest: compounds 1 and 2 (each within the scatter of the next); then compound 3.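

In this assay the aryl group on this oxygen turns out not to be indifferent: 3-methoxyphenyl in place of 4-methoxyphenyl gives a 2.9-fold higher number from compound 1 to compound 3 (0.47 log units; beyond the scatter), a modest step, whereas the exchange of 4-methoxyphenoxy for naphthalen-1-yl stayed within the scatter. The 3-methoxyphenoxy group also stands apart from naphthalen-1-yl on the aromatic carbon, with a 2.8-fold higher number from compound 2 to compound 3 (0.44 log units; beyond the scatter), so the placing of the methoxy on the outer ring matters more here than the change from the ether-linked ring to the two-ring aryl group. Nothing available accounts for this difference.

Open, as far as these compounds go, is how a plain phenoxy group would stand against the two methoxyphenoxy isomers, and whether a hydroxyl, a fluorine or an amine in place of the methoxy would follow compound 3 or compound 1. Also open, from the compounds shown here alone, is whether the same difference would hold with a longer chain.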